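Butylamino versus anilino on two related quinazoline-type cores

A few compounds are considered here, and "the series" means these few. Any claim that something is new, unique, unknown or untested is made for them only; others in the source may bear on it.

Compound 1 `CCCCNc1nc(NCc2ccccc2)c2ccccc2n1` and compound 3 `CCCCNc1nc(NCc2ccccc2)nc2ccccc12` are built from the same atoms joined differently; the difference between the two cores is not broken down here. In a physicochemical assay for lipophilicity, at pH 3 (on this read-out higher numbers stand for higher lipophilicity and lower numbers for lower lipophilicity), compound 1 gives 2.84, and in this assay compound 3 gives 2.86. The two numbers sit within the usual scatter of each other, so no order can be read between them.

Compound 2 `c1ccc(CNc2nc(Nc3ccccc3)nc3ccccc23)cc1` differs from compound 1 by phenyl in place of butyl on a nitrogen on an aromatic ring. In this assay compound 2 gives 2.78. The step of a number 0.06 log units lower from compound 1 to compound 2 (within the scatter) is within the scatter, so on this read-out the exchange of butyl for phenyl on the ring nitrogen leaves the number essentially where it was.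

Compound 4 `c1ccc(CNc2nc(Nc3ccccc3)c3ccccc3n2)cc1` has not yet been measured. It differs from compound 3 by phenyl in place of butyl on a nitrogen on an aromatic ring. Within the data shown here, the place of the change reads the same in both pairs, so this is the same change as the one from compound 1 to compound 2, now made on the core of compound 3. Among the measured compounds shown here, since compound 1 and compound 3 give values within the scatter of each other, and since the one measured instance of this change gave a number 0.06 log units lower from compound 1 to compound 2 (within the scatter), the expected step from compound 3 to compound 4 is a number 0.06 log units lower from compound 3 to compound 4 (within the scatter). On that basis compound 4 is estimated at 2.8 in this assay, with an expected range from 2.55 to 3.05.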

Compound 4, distribution coefficient: 2.67
The estimate for compound 4 lay 0.13 log units above the measured number; the range from low to high includes it.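

In this assay, butylamino to anilino on the nitrogen gives a number 0.19 log units lower from compound 3 to compound 4 (within the scatter) on one core and a number 0.06 log units lower from compound 1 to compound 2 (within the scatter) on the other, so the change stays within the scatter on both cores and the step carries from one to the other as no readable shift in lipophilicity. Among these compounds, this does not show that the change has a direction of its own, that the size of the step depends on the core, or that the same would hold on any core beyond these two, since the series offers only two such pairs, and neither step can be told from repeated measurement. Nothing shown here bears on why the two steps come out as they do.

The compounds shown leave open whether this stays true when the group on this nitrogen is something other than butyl or phenyl, such as a longer chain, a morpholine or a phenyl ring carrying a carboxylic acid. Going by these compounds, all four also keep the benzylamino group, so what happens to the step when a cyclohexylmethylamino group stands in its place remains open.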